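From methoxy to bromo: compound 4 awaits its cytotoxicity reading

This account rests on a few compounds, and the source may have more. Where it says the series, first, only, none or still open, it means among the compounds named here.

Compound 1 `Cc1ccc(/N=N/N(C)c2ccccc2)cc1` reads > 100000 nM
Compound 2 `COc1ccc(/N=N/N2CCCC2)cc1` reads >= 100000 nM
Compound 3 `CN(/N=N/c1cccc([N+](=O)[O-])c1)c1ccccc1` reads > 100000 nM

In an ADME assay on BHK-21 cells (Mesocricetus auratus) for cytotoxicity, read by MTT assay, with a stated time of 96 h (a higher number here means that more compound is tolerated, a lower number that less compound is tolerated), none of these three compounds gives a number. Compound 2 stands at >= 100000 nM as a limit and not a number. Compound 1 at > 100000 nM is a limit too. Compound 3 at > 100000 nM is a limit as well.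

Compound 4 `Brc1ccc(/N=N/N2CCCC2)cc1` differs from compound 2 by bromo in place of methoxy on an aromatic carbon in one place, with bromo in place of methoxy on an aromatic carbon. No measured step between any of these compounds shows what a change of this kind does in this assay. The expected at least 1.1-fold lower number from compound 2 to compound 4 (0.04 log units; that floor lies within the scatter) is no larger than the usual scatter, with no direction foreseen. Compound 2 at >= 100000 nM is the only anchor for this expectation and is itself a limit. For compound 4 the estimated half-maximal cytotoxic concentration is 90000 nM and the expected range runs from 40000 nM to 100000 nM on repeat measurement.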

Compound 4, half-maximal cytotoxic concentration: > 100000 nM
Compound 4 ended at the assay's limit; the forecaster's own chance of this, stated with the estimate: 60%; middle value at least 1.1-fold (0.04 log units) from the limit.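

Compound 2 and compound 4 both carry limits and not numbers, and the step between them cannot be read. In this assay the compounds shown leave open whether bromo in place of methoxy on an aromatic carbon shifts the half-maximal cytotoxic concentration at all, and where that concentration lies for any of the four.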